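Series notes: extending the ethyl of compound 1

The source may report more compounds than this note shows. Statements on the series, on what has been measured and on what is new or still open speak of the compounds shown alone.

Measured so far in a functional assay on the whole organism (B cells) with Mus musculus as the target; a higher number here means a larger maximal response, a lower number a smaller maximal response:
compound 1 `CCn1c(=O)n(C2OC(CO)[C@@H](O)[C@H]2O)c2nc(N)nc(O)c21` — 82%
compound 2 `C=CCn1c(=O)n(CCCCO)c2nc(N)nc(O)c21` — 12%
compound 3 `C=CCn1c(=O)n(C2C=CC(CO)O2)c2nc(N)nc(O)c21` — 45%

Compound 1 stands highest of the three numbers. Compound 3 lies next with 45%, and compound 2 lies furthest down with 12%; both gaps to compound 1 are beyond the scatter.

Among the compounds with values here, only one single-point step is available: a number 33 percentage points higher from compound 2 to compound 3 (beyond the scatter). It concerns the group on the other aromatic nitrogen of the shared core, not the site changed here, so it bears on compound 4 only by showing that this series can move a long way on one change.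

Compound 4 `Nc1nc(O)c2c(n1)n(C1OC(CO)[C@@H](O)[C@H]1O)c(=O)n2CC(O)CSc1ccccc1` differs from compound 1 by 1-hydroxy-2-(phenylsulfanyl)ethyl in place of methyl on a saturated chain carbon bound to an aromatic nitrogen. Within the data shown here, no measured pair varies this chain, so the direction is not fixed by the data. Given the large swing seen in a number 33 percentage points higher from compound 2 to compound 3 (beyond the scatter) for a change elsewhere, a sizeable move is expected rather than none; with compound 1 already near the top, a fall is estimated more likely than a rise, so for compound 4 the expected result is 55% (range 20% to 90%), an estimated step of a number 27 percentage points lower from compound 1 to compound 4 (beyond the scatter).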

Compound 4, largest response reached (reported as maximal response), in percent of the reference or control that the assay uses: 12%
Compound 4: the middle estimate sits 43 percentage points above what was measured; measured number below the stated range.
By their numbers in this assay, from the lowest: compounds 2 and 4 (each within the scatter of the next); then compound 3; then compound 1.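

In this assay, within the data shown here, the change from methyl to 1-hydroxy-2-(phenylsulfanyl)ethyl on a saturated chain carbon bound to an aromatic nitrogen gives a number 70 percentage points lower from compound 1 to compound 4 (beyond the scatter) as the first single-place step at this site. Among these compounds, the earlier step concerned the group on the other aromatic nitrogen, so this result is the first to show that this site also carries a large change in maximal response, and that this enlargement lowers it. Nothing on hand explains the fall.

The change brings in the hydroxyl and the phenylsulfanyl together, so the compounds shown do not separate their contributions. Also open, from the compounds shown here alone, is how a simple propyl or butyl chain, or a carboxylic acid or an amine on the same chain, would read out on this core.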